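Swapping methyl for trifluoromethyl on a second core

This account rests on a few compounds, and the source may have more. Where it says the series, first, only, none or still open, it means among the compounds named here.

Of the compounds shown here, three have been tested for their ability to hold back the growth of prostate cancer cells in a functional assay on PC-3 cells (Homo sapiens) for cytotoxicity, read by sulforhodamine B assay, with a stated time of 48 h, tested at 50 uM; on this read-out higher numbers stand for more inhibition at the one concentration tested (going by the name of the read-out) and lower numbers for less inhibition. Compound 3 `Cc1ccc(Nc2nccc(-c3cnc4ccccc4c3)n2)cc1` gives 59.5% in this assay, and compound 1 `FC(F)(F)c1ccc(Nc2nccc(-c3cnc4ccccc4c3)n2)cc1` gives 22.9%. The two differ in one place: trifluoromethyl in place of methyl on an aromatic carbon. That single change produced a number 36.6 percentage points lower from compound 3 to compound 1 (beyond the scatter).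

Compound 2 `Cc1ccc(Nc2nccc(-c3c(C)nc4ccccn34)n2)cc1` sits on a different core; how the two cores differ is not broken down here. In this assay compound 2 gives 94.2%, the highest of the three numbers.

Compound 4 `Cc1nc2ccccn2c1-c1ccnc(Nc2ccc(C(F)(F)F)cc2)n1` is not yet measured. It is related to compound 2 by the same change that links compound 3 to compound 1: trifluoromethyl in place of methyl on an aromatic carbon. Because the earlier change gave a number 36.6 percentage points lower from compound 3 to compound 1 (beyond the scatter), a comparable loss is expected on the second core, so the step is estimated as a number 36.2 percentage points lower from compound 2 to compound 4 (beyond the scatter). On that basis compound 4 is expected to give about 58% in this assay, most likely between 35% and 80%.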

Compound 4, a percentage reported as inhibition, at one concentration (the size of the read-out at that concentration, not a potency): 64.5%
Estimate against measurement, compound 4: 6.5 percentage points below; the range from low to high includes it.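

In this assay, putting trifluoromethyl in place of methyl on the second core gives a number 29.7 percentage points lower from compound 2 to compound 4 (beyond the scatter), so the drop seen on the first core appears here as well. Set side by side, the two steps do not differ by more than ordinary scatter allows, which means the change carried over from one core to the other with a similar size: the same change on two cores in this assay, a number 36.6 percentage points lower (beyond the scatter) from compound 3 to compound 1 and a number 29.7 percentage points lower (beyond the scatter) from compound 2 to compound 4, 6.9 percentage points apart, within the scatter of two such steps. Going by these compounds alone, this rests on only two pairs of compounds, read in a single assay at one concentration, so it does not show that the step would hold on any further core, and it does not explain why the number falls.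

The compounds shown carry only methyl or trifluoromethyl at this place on the ring, so what a chlorine atom, a methoxy group or a carboxylic acid would do there remains open. Also open, going by these compounds, is whether the step keeps its size in other cell lines or at other concentrations.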